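Removing the methyl from the ring amine of compound 2

A few compounds are considered here, and "the series" means these few. Any claim that something is new, unique, unknown or untested is made for them only; others in the source may bear on it.

Two compounds of this series have a measurement in an in vitro functional assay on SH-SY5Y cells for agonist activity at Neuronal acetylcholine receptor; alpha3/beta4 (Homo sapiens), read by FLIPR and calcium flux; on this read-out higher numbers stand for an effect only at larger amounts of compound and lower numbers for an effect already at smaller amounts. Compound 1 `Clc1ccncc1C1=CC2CNCC(C1)C2` gives 377 nM in this assay. Compound 2 `CN1C[C@H]2C=C(c3cccnc3)C[C@H](C2)C1` gives 7530 nM in this assay, the higher of the two numbers, and its gap to compound 1 lies beyond the usual scatter; the two differ in more than one place, so only the numbers themselves can be compared. Compound 3 `C1=C(c2cccnc2)C[C@H]2CNC[C@@H]1C2` has not yet been measured. It differs from compound 2 in one place: hydrogen in place of methyl on an amine nitrogen in a ring. Within the data shown here, no measured pair differs by this change alone, so its size here is unknown. Compound 1, which also carries a hydrogen on that amine nitrogen, gives 377 nM, which supports an expectation that compound 3 acts at smaller amounts than compound 2. The expected step, a 6.3-fold lower number from compound 2 to compound 3 (0.80 log units; beyond the scatter), points toward lower numbers. Compound 3 is estimated at 1200 nM, with a range from 300 nM to 4500 nM.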

Compound 3, half-maximal effective concentration: 37 nM
Compound 3: the middle estimate sits 32-fold (1.51 log units) above what was measured, and the stated range ends above it.
By their numbers in this assay, from the lowest: compound 3; then compound 1; then compound 2.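

In this assay, hydrogen in place of methyl on an amine nitrogen in a ring now has a measured size: a 200-fold lower number from compound 2 to compound 3 (2.31 log units; beyond the scatter). Among these compounds, no earlier pair isolated this change, so this is the first sign that a single methyl at this position, just one carbon among the heavy atoms, can shift the read-out so strongly. Nothing measured here accounts for the size of the step.

The compounds shown leave open how an ethyl group or a longer chain on this nitrogen would compare with methyl and with hydrogen. Among the compounds shown here, whether the change would give a step of similar size on the core of compound 1 also stays open, since only one pair speaks for it so far.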